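The source may hold more compounds than are shown below. What is called first, only, known or untested is meant among the compounds shown, and "the series" means these compounds.

Compound 1 `OC(c1ccc(Cl)cc1)(c1cccnc1)c1cccc(F)c1` is the reference point for this step. In an ADME assay on L6 cells (Rattus norvegicus) for cytotoxicity, read by resazurin assay, with a stated time of 72 h (on this read-out higher numbers stand for weaker inhibition and lower numbers for stronger inhibition), compound 1 gives 66000 nM, the lowest of the two numbers in hand. Compound 2 `CC(C)Oc1cccc(C(O)(c2ccc(Cl)cc2)c2cccnc2)c1` gives 67600 nM in this assay, a change of a 1.0-fold higher number from compound 1 to compound 2 (0.01 log units; within the scatter). Compound 3 `N#Cc1cccc(C(O)(c2ccc(Cl)cc2)c2cccnc2)c1` reaches only a limit of the assay, > 100000 nM in this assay, which is the limit of > 100000 nM in this assay, at which 1 of the 3 values shown sits. The steps of an at least 1.5-fold higher number from compound 1 to compound 3 (0.18 log units; that floor lies within the scatter) and an at least 1.4-fold higher number from compound 2 to compound 3 (0.17 log units; that floor lies within the scatter) have floors within the scatter. Compound 4 `Nc1ncc(C(O)(c2ccc(Cl)cc2)c2cccnc2)s1` is not yet measured; it differs from compound 1 by 2-amino-1,3-thiazol-5-yl in place of 3-fluorophenyl on a saturated chain carbon bound to two aromatic carbons and an oxygen on a saturated carbon. Among the measured compounds shown here, none of the measured steps exchanges the whole aryl group, so they bear on this change only loosely, and since each stays within the scatter no step beyond the scatter is expected in this assay. Compound 4 is estimated at 80000 nM, with a range from 40000 nM to 160000 nM. That estimate means an expected step of a 1.2-fold higher number from compound 1 to compound 4 (0.08 log units; within the scatter).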

Compound 4, half-maximal inhibitory concentration: 56000 nM
The estimate for compound 4 lay 1.4-fold (0.15 log units) above the measured number; measured number inside the range.
By their numbers in this assay, from the lowest: compounds 4, 1 and 2 (each within the scatter of the next). At a limit, above all of these: compound 3.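

Among the compounds shown here, compound 4 exchanges the whole aryl group on the saturated chain carbon, a change not covered by the earlier steps on an aromatic carbon. In this assay, 2-amino-1,3-thiazol-5-yl in place of 3-fluorophenyl gives a 1.2-fold lower number from compound 1 to compound 4 (0.07 log units; within the scatter), so this change of ring size and hetero atoms leaves the number within the scatter. Nothing in the data bears on the cause of this result.

Still open, going by these compounds, is whether a cyclohexyl group or a butyl chain in the same place would also stay within the scatter of compound 1.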